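The compounds below may be only part of what the source reports. "The series", "measured", "known", "first", "only" and "open" are said of these compounds alone.

Working notes on the dienone series.

Compound 1 `COc1cc(/C=C/C(=O)/C=C/c2cc(OC)c(OC)c(OC)c2)ccc1OCc1cn(CCOc2cc(=O)oc3ccccc23)nn1` carries a trimethoxyphenyl arm and the shortest linker of the set; in a functional assay on PC-3 cells (Homo sapiens) for inhibition, read by sulforhodamine B assay, with a stated time of 48 h, tested at 50 uM (on this read-out lower numbers stand for less inhibition of growth and higher numbers for more inhibition of growth at the one concentration tested), compound 1 gives 22%. Compound 2 `COc1ccccc1/C=C/C(=O)/C=C/c1ccc(OCc2cn(CCCCOc3cc(=O)oc4ccccc34)nn2)c(OC)c1` bears a 2-methoxyphenyl arm and a longer linker; in this assay compound 2 is recorded as "not active" (no number reported), with no number attached. Compound 3 `COc1cc(/C=C/C(=O)/C=C/c2ccco2)ccc1OCc1cn(CCCCCOc2cc(=O)oc3ccccc23)nn1` carries a furan-2-yl arm and the longest linker; in this assay compound 3 is likewise recorded as "not active" (no number reported). Where compound 2 stands can thus only be said in words: it shows no measurable growth inhibition at the single concentration, the same outcome as compound 3, while compound 1 alone yields a number.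

Compound 4 `COc1cc(/C=C/C(=O)/C=C/c2ccco2)ccc1OCc1cn(CCCCOc2cc(=O)oc3ccccc23)nn1` is the next entry, and it is reached from compound 2 by a single change: furan-2-yl in place of 2-methoxyphenyl on a double-bonded chain carbon bound to a double-bonded chain carbon. Going by the values given here, no measured pair shows this change directly, so the size of the step in this assay can only be expected. Given that compound 2 is recorded as "not active" (no number reported) and that compound 3, which already bears furan-2-yl, is recorded as "not active" (no number reported), no step beyond the scatter is expected in either direction. Compound 4 is therefore estimated at 8%, within 0% to 20%, with a fair chance that only a non-active outcome and no number is reported.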

Compound 4, percent growth inhibition at one concentration: "not active" (no number reported)
Compound 4 has no reported number here; no gap can be computed for the estimate.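

In this assay compound 2 is recorded as "not active" (no number reported) and compound 4 as "not active" (no number reported), so no step can be read for furan-2-yl in place of 2-methoxyphenyl. The compounds shown leave open whether this change has any effect on growth inhibition. No evidence at hand bears on this outcome.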